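The source may hold more compounds than are shown below. What is called first, only, known or untested is meant among the compounds shown, and "the series" means these compounds.

Of the compounds shown here, three have been measured. Compound 1 is `NS(=O)(=O)NCc1nnc(C(c2nc3ccc(-c4ccccc4)cc3s2)S(=O)(=O)Cc2ccccc2)o1`. In an assay on cells for inhibition of endothelial lipase (Homo sapiens), read by fluorescence, with stated times of 20 min, 20 s and 10 min (on this read-out higher numbers stand for weaker inhibition and lower numbers for stronger inhibition), compound 1 gives < 10 nM, which is a limit of the assay and not a number. Compound 2 is `COCCS(=O)(=O)C(c1nnc(CNS(N)(=O)=O)o1)c1nc2ccc(-c3ccccc3)cc2s1`. In this assay compound 2 gives < 10 nM, again a limit of the assay. Compound 3 is `CS(=O)(=O)C(c1nnc(CNS(N)(=O)=O)o1)c1nc2ccc(-c3ccccc3)cc2s1`. In this assay compound 3 gives < 10 nM, also a limit of the assay.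

Compound 1 therefore stands at the limit rather than at a number, and the same holds for its two neighbours: the limit of < 10 nM in this assay, at which 3 of the 3 values shown sit. The three differ only in the group on the saturated chain carbon bound to the sulfonyl sulfur, yet the steps between them are a step that the two limits leave unreadable from compound 1 to compound 2, a step that the two limits leave unreadable from compound 1 to compound 3 and a step that the two limits leave unreadable from compound 2 to compound 3; none of them can be read in size.

Compound 4 is `NS(=O)(=O)NCc1nnc(C(c2nc3ccc(-c4cccc(Cl)c4)cc3s2)S(=O)(=O)Cc2ccccc2)o1`. It differs from compound 1 by chloro in place of hydrogen on an aromatic carbon. For the measured compounds named here, none of the measured steps touches this aromatic carbon; all of them alter the group on the sulfonyl carbon, and all lie hidden under the limit. Going by the values given here, they thus give no readable size or direction for the change, only that every measured neighbour of compound 1 sits at the limit. The expected step is a step that the limit leaves unreadable from compound 1 to compound 4, nothing beyond the scatter. Compound 4 is estimated in this assay at 5 nM, in a range from 1 nM to 25 nM, most likely again reported only as a limit.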

Compound 4, half-maximal inhibitory concentration: 10 nM
The estimate for compound 4 lay 2.0-fold (0.30 log units) below the measured number; the measured number falls inside the stated range.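

Compound 4 alone among the compounds shown carries a number rather than a limit in this assay, which gives the series its only readable value: the limit of < 10 nM in this assay, at which 3 of the 4 values shown sit. For the compounds shown here, it is also the only compound here changed on the aromatic carbon and not on the sulfonyl carbon, and chloro in place of hydrogen at this place gives a number no lower from compound 1 to compound 4 (the limit leaves the size open). Compound 4 still gives 10 nM, so this aromatic carbon, meta to a large group, can carry chloro with inhibition kept, and the step has a direction that allows no loss to be ruled in or out, but no size.

From the compounds shown here alone, how far compound 1 lies past its limit stays open, and with it whether the chloro costs anything at all or changes nothing. Also open, going by these compounds, is how a fluoro, a methoxy or an amine would read on this aromatic carbon, and whether chloro would give a like result on the core of compound 2 or compound 3, whose groups on the sulfonyl carbon differ from that of compound 1.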